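The compounds below may be only part of what the source reports. "The series", "measured", "known", "first", "only" and "open" are said of these compounds alone.

Measured compounds:
compound 1 `CC(=O)Nc1ccc(-n2nncc2CN2C(=O)C3(C(C#N)=C(N)Oc4c3c3nc5ccccc5nc3c3ccccc43)c3ccccc32)cc1`, which in an ADME assay on HUVEC cells (Homo sapiens) for antiproliferative activity, read by MTT assay, with a stated time of 48 h (on this read-out higher numbers stand for weaker inhibition and lower numbers for stronger inhibition), gives > 50000 nM, a limit of the assay rather than a number;
compound 2 `N#CC1=C(N)Oc2c(N)cc3nc4ccccc4nc3c2C12C(=O)N(Cc1cnnn1-c1ccccc1Cl)c1ccccc12`, which in this assay gives > 50000 nM, likewise a limit and not a number.

Compound 2 therefore stands at the limit in this assay, and no number is known for it; the same holds for compound 1, since (the limit of > 50000 nM in this assay, at which 2 of the 2 values shown sit). Compound 3 `CCOc1ccc(-n2nncc2CN2C(=O)C3(C(C#N)=C(N)Oc4c(N)cc5nc6ccccc6nc5c43)c3ccccc32)cc1` has not yet been measured in this assay. It differs from compound 2 in one place: 4-ethoxyphenyl in place of 2-chlorophenyl on an aromatic nitrogen. Among the compounds with values here, no step between two measured compounds is available here, so the data give no measured size for a change of this kind. Because (the limit of > 50000 nM in this assay, at which 2 of the 2 values shown sit), the step of a number no higher from compound 2 to compound 3 (the limit leaves the size open) is expected to be none beyond the usual scatter, with the likely outcome again a limit rather than a number. Compound 3 is accordingly expected to give 50000 nM in this assay, within 20000 nM to 200000 nM.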

Compound 3, half-maximal inhibitory concentration: > 50000 nM
Compound 3: only a limit was reported (the forecaster's own chance of this, stated with the estimate: 80%); the middle value sits exactly at the limit.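

No step can be read from compound 2 to compound 3, since each gives only a limit and not a number: the limit of > 50000 nM in this assay, at which 3 of the 3 values shown sit.

The compounds shown leave open how strongly any of them acts in this assay, and whether 4-ethoxyphenyl and 2-chlorophenyl differ there at all.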